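The source may report more compounds than this note shows. Statements on the series, on what has been measured and on what is new or still open speak of the compounds shown alone.

Series notes. The shared core is that of compound 1 `NNC(=O)CSc1nnc(-c2ccncc2)o1`, which in a functional assay on HepG2 cells (Homo sapiens) for cytotoxicity, read by MTT assay, with a stated time of 48 h (a higher number here means a weaker inhibitor, a lower number a stronger inhibitor), gives 3260 nM. Compound 2 `O=C(CSc1nnc(-c2ccncc2)o1)N/N=C/c1ccc(F)cc1` gives 12300 nM in this assay, and compound 3 `O=C(CSc1nnc(-c2ccncc2)o1)N/N=C/c1ccc([N+](=O)[O-])cc1` gives 17900 nM. Compound 3 carries the highest number of the three in this assay: against compound 2 it lies within the scatter, against compound 1 beyond it. The one measured step among these, a 1.5-fold higher number from compound 2 to compound 3 (0.16 log units; within the scatter), is small. Compound 4 `O=C(CSc1nnc(-c2ccncc2)o1)N/N=C/c1cc(Cl)ccc1O` differs from compound 3 by 5-chloro-2-hydroxyphenyl in place of 4-nitrophenyl on a carbon with a double bond to nitrogen. Within the data shown here, only that single step bears on this change, and it stayed within the scatter; nothing measured covers the 5-chloro-2-hydroxyphenyl group. The expected step is therefore a 1.5-fold lower number from compound 3 to compound 4 (0.17 log units; within the scatter), nothing beyond the scatter. The estimate for compound 4 in this assay is 12000 nM, range 4000 nM to 36000 nM.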

Compound 4, half-maximal inhibitory concentration: 3970 nM
Compound 4: middle estimate off by 3.0-fold (0.48 log units), on the high side; measured number outside the range, below it.
By their numbers in this assay, from the lowest: compounds 1 and 4 (each within the scatter of the next); then compounds 2 and 3 (each within the scatter of the next).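

At the carbon with a double bond to nitrogen, 5-chloro-2-hydroxyphenyl gives a 4.5-fold lower number from compound 3 to compound 4 (0.65 log units; beyond the scatter) in this assay against 4-nitrophenyl, and a 3.1-fold lower number from compound 2 to compound 4 (0.49 log units; beyond the scatter) against 4-fluorophenyl. Among these compounds, the earlier swap at this place stayed within the scatter, so these are the first steps there to pass beyond it. No measurement on hand accounts for this shift.

Neither 2-hydroxyphenyl nor a chlorophenyl group alone is among the compounds shown, so the part played by each substituent stays open. Going by these compounds, how an aminophenyl or carboxyphenyl group would read at this place also stays open.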